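From pyridin-4-yl to furan-2-yl on the shared core

A few compounds are considered here, and "the series" means these few. Any claim that something is new, unique, unknown or untested is made for them only; others in the source may bear on it.

Measured in a functional assay on NCI-H1975 cells (Homo sapiens) for antiproliferative activity, read by MTT assay, with a stated time of 48 h; on this read-out higher numbers stand for weaker inhibition and lower numbers for stronger inhibition:
- Compound 1 `CC(C)c1ccc(-c2nc3cc(C(=O)N4CCC5(CC4)CC(=O)N(c4ccc(C(F)(F)F)cc4)C5)ccc3[nH]2)cc1`: > 10000 nM
- Compound 2 `O=C(c1ccc2[nH]c(-c3ccncc3)nc2c1)N1CCC2(CC1)CC(=O)N(c1ccc(C(F)(F)F)cc1)C2`: 390 nM

Compound 1 reaches only a limit of the assay, > 10000 nM. Among the measured compounds shown here, compound 2 therefore holds the only true number, 390 nM.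

The next compound is compound 3 `O=C(c1ccc2[nH]c(-c3ccco3)nc2c1)N1CCC2(CC1)CC(=O)N(c1ccc(C(F)(F)F)cc1)C2`, with furan-2-yl in place of pyridin-4-yl on an aromatic carbon. For the measured compounds named here, one measured step bears on this change, since it alters the same place: an at least 25-fold lower number from compound 1 to compound 2 (1.40 log units; beyond the scatter). That large step shows that the group here can move the number strongly in this assay, but it gives no direct reading for furan-2-yl. A moderate move towards weaker inhibition, smaller than that step, is expected. The estimated step is a 2.6-fold higher number from compound 2 to compound 3 (0.41 log units; beyond the scatter). For compound 3 the expected value is 1000 nM, with an estimated range of 200 nM to 6000 nM.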

Compound 3, half-maximal inhibitory concentration: 720 nM
Compound 3: the middle estimate sits 1.4-fold (0.14 log units) above what was measured, and the stated range covers the measured number.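

In this assay, replacing the six-membered pyridin-4-yl with the five-membered furan-2-yl gives a 1.8-fold higher number from compound 2 to compound 3 (0.27 log units; within the scatter), so the two groups cannot be told apart here, even though the ring size and the hetero atom both differ. Furan-2-yl also stays well clear of 4-isopropylphenyl, with an at least 13-fold lower number from compound 1 to compound 3 (1.14 log units; beyond the scatter), which shows that the gain seen with pyridin-4-yl does not depend on a ring nitrogen. Compound 1 stands at a limit of the assay, so this step gives only a bound: the limit of > 10000 nM in this assay, at which 1 of the 3 values shown sits.

Still open, going by these compounds, is whether the gain needs a hetero atom in the ring at all, or whether removing the isopropyl group alone would be enough. A plain phenyl ring on this carbon would separate these two readings, and a thiophen-2-yl group would test a further five-membered ring.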